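The compounds below may be only part of what the source reports. "The series", "measured", "known", "first", "only" and "open" are said of these compounds alone.

The series concerns three prostanoid-type esters examined in a functional assay on the whole organism (Cricetulus griseus) with Cricetinae gen. sp. as the target; a higher number here means that more compound is needed for the effect, a lower number that less compound is needed. Compound 1 has the structure `CCCC[C@](C)(OC)[C@@H](O)/C=C/C1[C@H](O)CC(=O)[C@@H]1C/C=C\CCCC(=O)OC`. In this assay compound 1 reaches only a limit, > 1 mg/kg, so no single number is known for it. Compound 2, `CCCC[C@](C)(OC)[C@@H](O)/C=C/C1[C@H](O)CC(=O)[C@@H]1CCCCCCC(=O)OC`, is the saturated-chain relative. In this assay compound 2 likewise yields only a limit, > 2.5 mg/kg; > 2.5 mg/kg (2 entries), in both of its entries. Thus compound 1 stands at the limit of > 1 mg/kg in this assay, at which 1 of the 2 values shown sits, and nothing measured so far gives a definite figure for either compound.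

Compound 3 has the structure `CCCC[C@@](C)(OC)[C@H](O)/C=C/C1[C@H](O)CC(=O)[C@@H]1C/C=C\CCCC(=O)OC`. It differs from compound 1 only in configuration: the two compounds have the same atoms and bonds; at least one stereo element is drawn with a configuration in one of them and without one in the other: 2 of 7 stereo elements differ; a stereocentre at a saturated chain carbon is drawn S in compound 1 and R in compound 3; a stereocentre at a saturated chain carbon is drawn S in compound 1 and R in compound 3. Going by the values given here, no measured step in this assay is available to calibrate the effect of such an inversion, so the direction of change from compound 1 to compound 3 cannot be read from the data; a step of moderate size in either direction would not be surprising. The expected value for compound 3 in this assay is 1.5 mg/kg, within a range of 0.2 mg/kg to 10 mg/kg, which corresponds to an expected step that the limit leaves unreadable from compound 1 to compound 3.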

Compound 3, dose for half-maximal effect: > 1 mg/kg
Compound 3: a limit, no number (the forecaster's own chance of this, stated with the estimate: 60%); the middle value lies beyond the limit too.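

Going by these compounds alone, compound 1 and compound 3 each reach only a limit in this assay, so no step between them can be read. The compounds shown leave open whether the two stereocentres that differ between them change the dose needed at all, and in which direction.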